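Amide Nitrogen Substituent Change and Cytotoxicity Limits

A few compounds are considered here, and "the series" means these few. Any claim that something is new, unique, unknown or untested is made for them only; others in the source may bear on it.

Compound 1 `C=CC1=C(C(=O)NCc2ccc(C)cc2)C(c2ccc(F)cc2)OC1` in a functional assay on A549 cells (Homo sapiens) for cytotoxicity, read by MTT assay, with a stated time of 24 h (on this read-out higher numbers stand for weaker inhibition and lower numbers for stronger inhibition), reaches only a limit of > 100000 nM.
Compound 2 `C=CC1=C(C(=O)Nc2ccccc2OC)C(c2ccc(F)cc2)OC1` in this assay likewise reaches only a limit of > 100000 nM.

Compound 2 therefore stands at the limit of this assay, a position it shares with compound 1, as the limit of > 100000 nM in this assay, at which 2 of the 2 values shown sit, records. Among the measured compounds shown here, the one step between the measured compounds, a step that the two limits leave unreadable from compound 1 to compound 2, cannot be read because both of its ends are limits.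

Compound 3 `C=CC1=C(C(=O)NCC(C)C)C(c2ccc(F)cc2)OC1` differs from compound 2 by isobutyl in place of 2-methoxyphenyl on an amide-type nitrogen. For the measured compounds named here, no measured step bears readably on this change, since the only step available, a step that the two limits leave unreadable from compound 1 to compound 2, is unreadable. With nothing in the numbers pointing to inhibition within the range of this assay, compound 3 is expected to remain at or near the limit as well. Compound 3 is therefore estimated at 150000 nM, with a range from 50000 nM to 600000 nM, which as an expected step from compound 2 means a step that the limit leaves unreadable from compound 2 to compound 3.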

Compound 3, half-maximal inhibitory concentration: > 100000 nM
Compound 3 ended at the assay's limit; the forecaster's own chance of this, stated with the estimate: 85%; the middle value is on the limit's open side.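

Compound 3 also gives only a limit in this assay, > 100000 nM, so the steps linking it to compound 1 and compound 2 cannot be read. The compounds shown leave open whether any amide nitrogen substituent on the shared core gives a measurable value: the limit of > 100000 nM in this assay, at which 3 of the 3 values shown sit.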